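Sulfonyl group change on compound 1: permeability outlook

The source may hold more compounds than are shown below. What is called first, only, known or untested is meant among the compounds shown, and "the series" means these compounds.

Of the three compounds measured in an ADME assay on MDCK cells (Canis lupus familiaris) for permeability, in the apical to basolateral direction (on this read-out higher numbers stand for higher permeability and lower numbers for lower permeability), compound 1 `O=C(NCc1ccc(S(=O)(=O)c2cc(F)cc(F)c2)cc1)c1cc2ccncc2o1` gives 14 10^-6 cm/s. This is the highest number shown, but compound 2 `O=C(NCc1ccc(S(=O)(=O)c2cc(F)cc(F)c2)cc1)c1cc2cnccc2[nH]1` at 13 10^-6 cm/s lies within the scatter of it. Compound 3 `O=C(NCc1ccc(S(=O)(=O)C2CCOCC2)cc1)c1cc2cnccc2[nH]1` gives 0.9 10^-6 cm/s, well under both.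

Compound 4 `CC(C)N1CCC(S(=O)(=O)c2ccc(CNC(=O)c3cc4ccncc4o3)cc2)CC1` has not yet been measured. Its difference from compound 1 is 1-isopropylpiperidin-4-yl in place of 3,5-difluorophenyl on a sulfonyl sulfur, with the rest of the structure kept.

Among the compounds with values here, two measured steps bear on this. The change on the carbonyl carbon gave a 1.1-fold lower number from compound 1 to compound 2 (0.03 log units; within the scatter), so that exchange made no visible difference here. The closer precedent is a 14-fold lower number from compound 2 to compound 3 (1.16 log units; beyond the scatter), a large step in which oxan-4-yl replaces the same 3,5-difluorophenyl at the same sulfonyl sulfur. Within the data shown here, it is a single case with a different incoming group, and no measured compound carries 1-isopropylpiperidin-4-yl, so its transfer to compound 4 is uncertain. A large fall of similar size is still the expectation. The expected step in this assay is a 9.3-fold lower number from compound 1 to compound 4 (0.97 log units; beyond the scatter). Compound 4 is estimated at 1.5 10^-6 cm/s, with an expected range of 0.4 10^-6 cm/s to 6 10^-6 cm/s.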

Compound 4, apparent permeability: 8 10^-6 cm/s
The estimate for compound 4 lay 5.3-fold (0.73 log units) below the measured number; measured number above the stated range.
By their numbers in this assay, from the lowest: compound 3; then compounds 4, 2 and 1 (each within the scatter of the next).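

In this assay, the sulfonyl sulfur position does not respond to every replacement of 3,5-difluorophenyl with a large fall: 1-isopropylpiperidin-4-yl gives a 1.8-fold lower number from compound 1 to compound 4 (0.24 log units; within the scatter), whereas oxan-4-yl gave a 14-fold lower number from compound 2 to compound 3 (1.16 log units; beyond the scatter). Losing the aromatic ring at this place therefore does not by itself go with a large step, with compound 3 as the one case against compound 4, so the outcome depends on the incoming group or on the rest of the structure. Nothing at hand accounts for the contrast between these two steps.

The two non-aromatic groups sit on different groups at the carbonyl carbon, and the exchange there was within the scatter only with 3,5-difluorophenyl on the sulfonyl sulfur (compound 1 and compound 2), so the two replacements cannot yet be set directly against each other. Also open, as far as these compounds go, is whether piperidin-4-yl without the isopropyl group, or an open-chain amine on the sulfonyl sulfur, would stay within the scatter of compound 1 or would show a large fall like the step to compound 3.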